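This account rests on a few compounds, and the source may have more. Where it says the series, first, only, none or still open, it means among the compounds named here.

Measured in a functional assay on PC-3 cells (Homo sapiens) for cytotoxicity, read by MTT assay, with a stated time of 48 h; a higher number here means a weaker inhibitor, a lower number a stronger inhibitor:
Compound 1 `O=C(O)CN1C(=O)/C(=C/c2nc3ccccc3n2Cc2ccccc2F)SC1=S`: 1860 nM
Compound 2 `Cc1ccc(Cn2c(/C=C3\SC(=S)N(CCC(=O)O)C3=O)nc3ccccc32)cc1`: 9310 nM
Compound 3 `O=C1NC(=S)S/C1=C\c1nc2ccccc2n1Cc1ccccc1F`: > 50000 nM, a limit and not a number

Compound 3 has no number of its own and stands only at the limit of > 50000 nM in this assay, at which 1 of the 3 values shown sits. Compound 4 `O=C(O)CCN1C(=O)/C(=C/c2nc3ccccc3n2Cc2ccccc2F)SC1=S` carries 2-carboxyethyl in place of hydrogen on an amide-type nitrogen in a ring. Within the data shown here, the one measured step that bears on this is an at least 26-fold higher number from compound 1 to compound 3 (1.42 log units; beyond the scatter), which runs the opposite way with carboxymethyl on that nitrogen. It is large and beyond the scatter. Compound 2, which has the same 2-carboxyethyl group but a different remainder, gives 9310 nM. A large drop in the number is therefore expected in this assay. The estimated change is an at least 12-fold lower number from compound 3 to compound 4 (1.09 log units; beyond the scatter). Compound 4 is expected at 4000 nM, within an estimated range of 1200 nM to 15000 nM.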

Compound 4, half-maximal inhibitory concentration: 28600 nM
For compound 4 the middle estimate is 7.2-fold (0.85 log units) below the measured one; the whole stated range lies below it.
By their numbers in this assay, from the lowest: compound 1; then compound 2; then compound 4. At a limit, above all of these: compound 3.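

Compound 3 stays a limit and not a number: the limit of > 50000 nM in this assay, at which 1 of the 4 values shown sits.

In this assay, adding 2-carboxyethyl to that nitrogen therefore gives only a floor, with an at least 1.7-fold lower number from compound 3 to compound 4 (0.24 log units; that floor lies within the scatter). The length of the acid chain at this position counts for far more, with a 15-fold higher number from compound 1 to compound 4 (1.19 log units; beyond the scatter), and the change at the other end of the molecule also counts, though less, with a 3.1-fold higher number from compound 2 to compound 4 (0.49 log units; beyond the scatter).

From the compounds shown here alone, whether a longer chain on this nitrogen would raise the number further remains open. So does whether an amine in place of the carboxylic acid would keep the activity of compound 1.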